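Swapping 4-Nitrophenyl for 2-Fluorophenyl on the Ring Amine

The compounds below may be only part of what the source reports. "The series", "measured", "known", "first", "only" and "open" are said of these compounds alone.

Measured so far:
compound 1, `COc1cc(N)c(Cl)cc1NC(=O)C1CCN(CC2CCCCC2)CC1`: 2.9 mg/kg
compound 2, `COc1cc(N)c(Cl)cc1NC(=O)C1CCN(Cc2ccc([N+](=O)[O-])cc2)CC1`: > 4 mg/kg

In a functional assay on the whole organism for antagonist activity, with Mus musculus as the target (on this read-out higher numbers stand for an effect only at larger amounts of compound and lower numbers for an effect already at smaller amounts), compound 1 gives 2.9 mg/kg. For compound 2 this assay reports only a limit, > 4 mg/kg. The step is therefore an at least 1.3-fold higher number from compound 1 to compound 2 (0.13 log units; that floor lies within the scatter), and its floor rests on (the limit of > 4 mg/kg in this assay, at which 1 of the 2 values shown sits), so compound 2 stands at an undetermined distance above compound 1, possibly within the scatter.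

Compound 3, `COc1cc(N)c(Cl)cc1NC(=O)C1CCN(Cc2ccccc2F)CC1`, differs from compound 2 by 2-fluorophenyl in place of 4-nitrophenyl on a saturated chain carbon bound to an amine nitrogen in a ring.

Going by the values given here, only the step from compound 1 to compound 2 bears on this change, and it links cyclohexyl to 4-nitrophenyl; neither measured compound carries 2-fluorophenyl, so no step shows its effect directly. As 2-fluorophenyl returns towards the size of cyclohexyl in compound 1 with its 2.9 mg/kg, compound 3 is expected to land near that value, which means an expected step of an at least 1.3-fold lower number from compound 2 to compound 3 (0.12 log units; that floor lies within the scatter). The estimate for compound 3 in this assay is 3 mg/kg, with a range from 1 mg/kg to 9 mg/kg.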

Compound 3, dose for half-maximal effect: > 4 mg/kg
Compound 3: a limit, no number; the forecaster's own chance of this, stated with the estimate: 35%; at least 1.3-fold (0.12 log units) between middle value and limit.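

In this assay, going by these compounds alone, 2-fluorophenyl on a saturated chain carbon bound to an amine nitrogen in a ring ends in a limit, as 4-nitrophenyl did, so two different phenyl groups at this place have now failed to give a number, and cyclohexyl in compound 1 remains the only group here with one. Measured against cyclohexyl, the change gives an at least 1.3-fold higher number from compound 1 to compound 3 (0.13 log units; that floor lies within the scatter), so the result sets only a floor and does not establish a real difference between 2-fluorophenyl and cyclohexyl. The step between the two phenyl compounds cannot be read, and 4-nitrophenyl and 2-fluorophenyl cannot be put in any order, since both results rest on the same ceiling: the limit of > 4 mg/kg in this assay, at which 2 of the 3 values shown sit.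

From the compounds shown here alone, how far compound 2 and compound 3 actually lie from compound 1 stays open, and either could still sit close to it or far from it. Also open, going by these compounds, is whether an unsubstituted phenyl, a 4-methoxyphenyl or a longer chain carrying the cyclohexyl at this place would give a real number in this assay and so show what this position tolerates.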